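The compounds below may be only part of what the source reports. "The series", "measured", "known", "first", "only" and "open" are said of these compounds alone.

Measured so far in an ADME assay on HepG2 cells (Homo sapiens) for cytotoxicity, read by CellTiter-Glo and resazurin assay, with a stated time of 72 h; a higher number here means that more compound is needed for the effect, a lower number that less compound is needed:

Compound 1 `CC(C)COc1cccc(-c2ccc(C(=O)N(Cc3cccc(OCCCCCC(=O)O)c3)C(C)C)cc2)c1` gives > 26000 nM in this assay, which is a limit of the assay and not a number.
Compound 2 `CC(C)N(Cc1cccc(OCCCCCC(=O)O)c1)C(=O)c1ccc(-c2ccoc2)cc1` gives > 26000 nM in this assay, again a limit.
Compound 3 `CCOC(=O)CCCCCOc1cccc(CN(C(=O)c2ccc(-c3ccc(C(C)=O)s3)cc2)C(C)C)c1` gives > 26000 nM in this assay, again a limit.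

Compound 3 thus stands only at a limit, and the two further values are limits as well: all three sit at the limit of > 26000 nM in this assay, at which 3 of the 3 values shown sit. Going by the values given here, the single measured step, a step that the two limits leave unreadable from compound 1 to compound 2, has both ends at that limit and gives no size to read.

Compound 4 `CCOC(=O)CCCCCOc1cccc(CN(C(=O)c2ccc(-c3cccc([N+](=O)[O-])c3)cc2)C(C)C)c1` differs from compound 3 by 3-nitrophenyl in place of 5-acetylthiophen-2-yl on an aromatic carbon. Among the compounds with values here, no measured step touches this part of the structure, and the one step that exists is unreadable, so nothing indicates a size or a direction for this assay. The expectation therefore rests on the three limits alone: compound 4 is expected to sit at the limit like the rest, an estimated 35000 nM with a range from 15000 nM to 120000 nM, meaning an expected step that the limit leaves unreadable from compound 3 to compound 4, which is none beyond the scatter.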

Compound 4, half-maximal effective concentration: > 26000 nM
Compound 4 ended at the assay's limit; the forecaster's own chance of this, stated with the estimate: 85%; the middle value lies beyond the limit too.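

In this assay compound 4 gives > 26000 nM, a limit of the assay and not a number. Going by these compounds alone, compound 3 also stands at a limit, and no step between compound 3 and compound 4 can be read. The compounds shown leave open what concentration any of them needs for the half-maximal effect.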